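Amide cap variation on the hydroxamate series

The source may hold more compounds than are shown below. What is called first, only, known or untested is meant among the compounds shown, and "the series" means these compounds.

Measured so far:
compound 1 `O=C(CCCCC[C@H](NC(=O)c1cc2ccccc2[nH]1)C(=O)NCc1ccccc1)NO` — 1260 nM
compound 2 `O=C(CCCCC[C@H](NC(=O)c1ccc(C(F)(F)F)cc1)C(=O)NCc1ccccc1)NO` — 1610 nM

Both compounds share the hydroxamic acid chain, the benzylamide and the amide-linked cap; only the cap differs. In a functional assay on NFF cells (Homo sapiens) for antiproliferative activity (on this read-out lower numbers stand for stronger inhibition and higher numbers for weaker inhibition), compound 1 gives 1260 nM and compound 2 gives 1610 nM. Among the measured compounds shown here, the one measured step, a 1.3-fold higher number from compound 1 to compound 2 (0.11 log units; within the scatter), lies within the scatter, so the two caps cannot be told apart on these numbers. Compound 2 has the highest number of the two, but the gap to compound 1 is within the scatter.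

Compound 3 `O=C(CCCCC[C@H](NC(=O)c1cc2c(Br)cccc2[nH]1)C(=O)NCc1ccccc1)NO` is not yet measured. It differs from compound 2 by 4-bromo-1H-indol-2-yl in place of 4-(trifluoromethyl)phenyl on a carbonyl carbon. This returns the indole cap of compound 1, now carrying a bromine. For the measured compounds named here, the only step that bears on it, a 1.3-fold higher number from compound 1 to compound 2 (0.11 log units; within the scatter), was within the scatter, and no measured step speaks to the bromine. Compound 3 is therefore expected to land near compound 1, with a 1.5-fold lower number from compound 2 to compound 3 (0.17 log units; within the scatter) expected to stay small. The estimate for compound 3 in this assay is 1100 nM, within 450 nM to 2700 nM.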

Compound 3, half-maximal inhibitory concentration: 1940 nM
Compound 3: middle estimate off by 1.8-fold (0.25 log units), on the low side; measured number inside the range.
By their numbers in this assay, from the lowest: compounds 1, 2 and 3 (each within the scatter of the next).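

In this assay, among the compounds shown here, bromo in place of hydrogen on an aromatic carbon of the 1H-indol-2-yl cap gives a 1.5-fold higher number from compound 1 to compound 3 (0.19 log units; within the scatter) and is the first read on a substituent on that cap. Placing 4-bromo-1H-indol-2-yl on the carbonyl carbon instead of 4-(trifluoromethyl)phenyl gives a 1.2-fold higher number from compound 2 to compound 3 (0.08 log units; within the scatter) and so leaves the three caps shown unresolved from one another. No available data bear on why these caps read alike.

On these data alone, whether a cap carrying an amine or a carboxylic acid would give a step beyond the scatter remains open. Also open is how a longer chain in place of the present hydroxamic acid chain, or a methyl group in place of the benzyl group on the amide, would read in this assay against the compounds shown.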